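This account rests on a few compounds, and the source may have more. Where it says the series, first, only, none or still open, it means among the compounds named here.

Measured in an ADME assay (liver) for metabolic stability, with Liver microsome (Rattus norvegicus) as the target, using microsomes and NADPH, with a stated time of 30 min, at 37 degrees C, tested at 1 uM; on this read-out lower numbers stand for slow clearance and higher numbers for fast clearance:
- compound 1 `CC(O)(c1ccc(-c2ccc(S(=O)(=O)c3ccc(N)nc3)nc2Nc2ccccc2)nc1)C(F)(F)F` gives 100 mL.min-1.g-1
- compound 2 `C[C@@](O)(c1ccc(-c2ncc(S(=O)(=O)c3ccc(N)nc3)s2)c(Cl)c1)C(F)(F)F` gives < 14 mL.min-1.g-1 (a limit of the assay)
- compound 3 `C[C@](O)(c1ccc(-c2ncc(S(=O)(=O)c3ccc(N)nc3)s2)c(Cl)c1)C(F)(F)F` gives < 14 mL.min-1.g-1 (a limit of the assay)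

Compound 3 stands at < 14 mL.min-1.g-1 in this assay, and this is a limit of the assay, not a number (the limit of < 14 mL.min-1.g-1 in this assay, at which 2 of the 3 values shown sit). Compound 4 `Nc1ccc(S(=O)(=O)c2cnc(-c3ccc(S(N)(=O)=O)cc3Cl)s2)cn1` has sulfamoyl in place of 1-hydroxy-1-(trifluoromethyl)ethyl on an aromatic carbon, meta to a chloro group (sulfamoyl in place of 1-hydroxy-1-(trifluoromethyl)ethyl on an aromatic carbon). Going by the values given here, the only measured step is a step that the two limits leave unreadable from compound 2 to compound 3. Among the compounds with values here, it concerns configuration alone (the fact that compounds 2 and 3 differ only in the configuration as drawn) and leaves this group in place, so no measured step gives a size for the exchange. Within the data shown here, compound 1 gives 100 mL.min-1.g-1, but no single-place step links it to the others. The expectation therefore rests on compound 3 and its limit of < 14 mL.min-1.g-1, with slow clearance expected to persist and another report as a limit quite likely. The expected change is a step that the limit leaves unreadable from compound 3 to compound 4, with no clear shift beyond the scatter in this assay. For compound 4 the estimated value is 11 mL.min-1.g-1, with an expected range from 5 mL.min-1.g-1 to 30 mL.min-1.g-1.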

Compound 4, intrinsic clearance in microsomes: 107 mL.min-1.g-1
Compound 4: the middle estimate sits 9.7-fold (0.99 log units) below what was measured; the measured number lies above the stated range.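

In this assay, this position on the six-membered aromatic ring of carbon only can move the read-out: sulfamoyl in place of 1-hydroxy-1-(trifluoromethyl)ethyl gives an at least 7.6-fold higher number from compound 3 to compound 4 (0.88 log units; beyond the scatter), and the same exchange gives an at least 7.6-fold higher number from compound 2 to compound 4 (0.88 log units; beyond the scatter). As far as these compounds go, the low read-out therefore does not hold for the shared core whatever stands at this position, and the full size of the exchange stays unknown, because both starting compounds sit at a limit of the assay: the limit of < 14 mL.min-1.g-1 in this assay, at which 2 of the 4 values shown sit. The exchange reads the same from either drawn configuration of the group that leaves, while the step between those two compounds cannot be read: the fact that compounds 2 and 3 differ only in the configuration as drawn.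

From the compounds shown here alone, whether the rise follows from the arrival of sulfamoyl or from the loss of 1-hydroxy-1-(trifluoromethyl)ethyl remains open. An amine or a carboxylic acid at this position would help to separate the two.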